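Two Cores, One Swap, One Expected Loss

This account rests on a few compounds, and the source may have more. Where it says the series, first, only, none or still open, it means among the compounds named here.

Of the compounds shown here, three have been tested in a functional assay on Bel-7402 cells (Homo sapiens) for antiproliferative activity, read by MTT assay, with a stated time of 72 h; on this read-out lower numbers stand for stronger inhibition and higher numbers for weaker inhibition. Compound 1, `Cc1ccccc1NC1=C/C(=N/NC(N)=S)C(=O)N=C1Nc1ccccc1C`, gives 1710 nM in this assay . Compound 2, `Cc1ccc(NC2=C/C(=N/NC(N)=S)C(=O)N=C2Nc2ccc(C)cc2)cc1`, is built from the same atoms as compound 1 joined in a different way; the difference between the two cores is not broken down here. In this assay compound 2 gives 4330 nM. Compound 3, `Cc1ccccc1NC1=C/C(=N/N=C(\N)SCc2ccccc2)C(=O)N=C1Nc1ccccc1C`, shares the core of compound 1 but carries a different group: a group of 11 heavy atoms (8 carbon, 2 nitrogen, 1 sulfur; one six-membered aromatic ring of carbon only) in place of a group of 4 heavy atoms (1 carbon, 2 nitrogen, 1 sulfur; no ring), on a double-bonded nitrogen. In this assay compound 3 gives 17100 nM. This change brought a 10-fold higher number from compound 1 to compound 3 (1.00 log units; beyond the scatter) in this assay , so the larger group went with weaker inhibition on that core.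

Compound 4, `Cc1ccc(NC2=C/C(=N/N=C(\N)SCc3ccccc3)C(=O)N=C2Nc2ccc(C)cc2)cc1`, has not yet been measured. It stands to compound 2 exactly as compound 3 stands to compound 1: a group of 11 heavy atoms (8 carbon, 2 nitrogen, 1 sulfur; one six-membered aromatic ring of carbon only) in place of a group of 4 heavy atoms (1 carbon, 2 nitrogen, 1 sulfur; no ring), on a double-bonded nitrogen. The place where the change happens is described in the same words for both pairs, so this is the same change, made on the other core.

Within the data shown here, only one measured example of this change exists, so the expectation rests on it alone. Starting from compound 2 and applying a step of the size seen from compound 1 to compound 3, compound 4 is expected to show a 9.9-fold higher number from compound 2 to compound 4 (1.00 log units; beyond the scatter) in this assay . On that basis compound 4 is estimated at 43000 nM, with a plausible range from 15000 nM to 120000 nM, given that the two cores may not respond alike.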

Compound 4, half-maximal inhibitory concentration: 7680 nM
For compound 4 the middle estimate is 5.6-fold (0.75 log units) above the measured one; measured number below the stated range.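

On the core of compound 2, the same swap gave a 1.8-fold higher number from compound 2 to compound 4 (0.25 log units; within the scatter), so in this assay the two compounds on this core cannot be told apart. Set beside the step on the core of compound 1, the change did not carry over at the same size, and the difference between the two cores' responses is larger than repeat measurements would explain: the same change on two cores in this assay, a 10-fold higher number (1.00 log units; beyond the scatter) from compound 1 to compound 3 and a 1.8-fold higher number (0.25 log units; within the scatter) from compound 2 to compound 4, 5.6-fold (0.75 log units) apart, beyond the scatter of two such steps

Among these compounds, this shows that a large loss seen with this change on one core need not appear on a closely related one, so a step measured once is a weak guide to the same step elsewhere, but with only two pairs it does not show what in the two cores sets their responses apart, or which of them is the more typical.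

As far as these compounds go, it remains open how a third core would respond, for example one with chlorine atoms where these cores have methyl groups. From the compounds shown here alone, it is also open whether a smaller group on the sulfur, such as a methyl or an ethyl chain, would give a step that matches more closely across the two cores, or whether an amine or a carboxylic acid on the aromatic ring of the entering group would do so.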